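Swapping the hydroxyphenyl arm of compound 1 for pyridine

The source may report more compounds than this note shows. Statements on the series, on what has been measured and on what is new or still open speak of the compounds shown alone.

Measured compounds:
compound 1 `Oc1cc(F)ccc1C(c1ccc2ccoc2c1O)N1CCCCC1`: 1070 nM
compound 2 `Cc1ccnc(NC(c2ccc(C(F)(F)F)cc2)c2ccc3cccnc3c2O)c1`: 26500 nM
compound 3 `Oc1ccc2ccncc2c1C(c1ccc(F)cc1)N1CCCCC1`: 10200 nM

In an assay for inhibition of protein disulfide-isomerase (Homo sapiens), with a stated time of 1 h (a lower number here means a stronger inhibitor, a higher number a weaker inhibitor), compound 1 gives 1070 nM, the lowest of the three numbers and therefore the strongest inhibitor in this set. The nearest of the others is compound 3, which gives 10200 nM in this assay, a gap that lies beyond the usual scatter. Furthest away is compound 2, which gives 26500 nM, also well beyond the scatter. Among the compounds with values here, each of these three compounds has its own core, so no two of them differ in a single place, and no step between measured compounds can be drawn.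

Compound 4 `Oc1c(C(c2ccncc2)N2CCCCC2)ccc2ccoc12` has not yet been measured in this assay. It keeps the core of compound 1 and the ring amine, and differs in one place: pyridin-4-yl in place of 4-fluoro-2-hydroxyphenyl on a saturated chain carbon bound to an amine nitrogen in a ring and an aromatic carbon. The group that leaves carries a hydrogen-bond donor and a fluorine; the group that enters carries neither. The measured compounds give no direct guide to this exchange, since none of them differ in only this place. On the grounds that compound 1, which gives 1070 nM, is the only one of the three carrying that donor-bearing arm, compound 4 is expected to be a somewhat weaker inhibitor, with an estimated step of a 4.7-fold higher number from compound 1 to compound 4 (0.67 log units; beyond the scatter) in this assay. For compound 4 the estimate is 5000 nM, in a range from 1500 nM to 20000 nM.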

Compound 4, half-maximal inhibitory concentration: < 200 nM
Compound 4: a limit, no number; the forecaster's own chance of this, stated with the estimate: 15%; middle value at least 25-fold (1.39 log units) from the limit.
By their numbers in this assay, from the lowest: compound 1; then compound 3; then compound 2. At a limit, below all of these: compound 4.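

In this assay compound 4 gives < 200 nM, which is a limit of the assay and not a number: the limit of < 200 nM in this assay, at which 1 of the 4 values shown sits.

Going by these compounds, putting pyridin-4-yl in place of 4-fluoro-2-hydroxyphenyl on this saturated chain carbon gives an at least 5.3-fold lower number from compound 1 to compound 4 (0.72 log units; beyond the scatter), so the exact size of the step stays unknown, but its direction is clear. The earlier compounds shown here could suggest that the hydrogen-bond donor of the arm in compound 1 mattered, yet this single exchange shows that, on this core and with this ring amine, strong inhibition does not depend on that donor or on the fluorine, since the entering group carries neither.

The exchange removes the hydroxy group and the fluorine and brings in a ring nitrogen all at once, so the compounds shown cannot tell which of these changes accounts for the lower number. A plain phenyl ring would separate the loss of those two groups from the gain of the nitrogen, and pyridin-3-yl would test whether the place of that nitrogen in the ring matters.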